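Adding a formyl group to compound 1

The compounds below may be only part of what the source reports. "The series", "measured", "known", "first", "only" and "open" are said of these compounds alone.

Measured in a functional assay on SH-SY5Y cells (Homo sapiens) for cytotoxicity, read by MTT assay; a higher number here means a weaker inhibitor, a lower number a stronger inhibitor:
- compound 1 `COc1ccc(-c2cocc2-c2cc(OC)c(OC)c(OC)c2)cc1` gives 39 nM
- compound 2 `COc1ccc(-c2cocc2-c2cc(OC)c(OC)c(OC)c2)cc1[N+](=O)[O-]` gives 245 nM

Compound 1 has the lower number of the two, so it is the stronger inhibitor of this pair. Compound 3 `COc1ccc(-c2c(-c3cc(OC)c(OC)c(OC)c3)coc2C=O)cc1` keeps the core of compound 1 and changes in one place: formyl in place of hydrogen on an aromatic carbon. Put simply, the new formyl group sits next to the ring oxygen. Among the compounds with values here, only one measured step bears on this: a 6.3-fold higher number from compound 1 to compound 2 (0.80 log units; beyond the scatter). That step also replaced a hydrogen on an aromatic carbon, but with nitro and at a different place, so it is only a loose guide. A modest step toward a higher number in this assay is therefore expected, perhaps somewhat smaller than that one. For compound 3 the expected value is 130 nM, with an estimated range from 30 nM to 600 nM. This estimate amounts to a 3.3-fold higher number from compound 1 to compound 3 (0.52 log units; beyond the scatter).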

Compound 3, half-maximal inhibitory concentration: 231 nM
Compound 3: the middle estimate sits 1.8-fold (0.25 log units) below what was measured; low and high end bracket the measured number.
By their numbers in this assay, from the lowest: compound 1; then compounds 3 and 2 (each within the scatter of the next).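

In this assay, putting a formyl group on the aromatic carbon next to the ring oxygen gives a 5.9-fold higher number from compound 1 to compound 3 (0.77 log units; beyond the scatter) of the shared core. Within the data shown here, this is the first direct reading at this carbon of the five-membered aromatic ring, since compound 2 carries its nitro group at a different place, and it shows that this hydrogen cannot be replaced by formyl without a clear rise in the number. Nothing available explains this rise.

With formyl as the only group shown at this carbon, the result cannot separate an effect of formyl itself from one shared by any replacement of the hydrogen. A methyl, a hydroxymethyl, an amine or a carboxylic acid here might stay close to what compound 1 gives, 39 nM or might not.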